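Iodo in Place of Ethyl: What Compound 4 Might Show

The source may hold more compounds than are shown below. What is called first, only, known or untested is meant among the compounds shown, and "the series" means these compounds.

compound 1 `CCc1ccccc1-c1nc(N)nc(N)n1` — 20%
compound 2 `Nc1nc(N)nc(-c2cc(Br)ccc2F)n1` — 100%
compound 3 `Nc1nc(N)nc(-c2cc(F)ccc2Br)n1` — 78%

In a functional assay on the whole organism with Rattus norvegicus as the target, at a dose of 20 mg/kg by the intraperitoneal route (a higher number here means more inhibition at the dose given (going by the name of the read-out), a lower number less inhibition), compound 1 gives 20%, the lowest of the three numbers. Compound 3 stands above it by a margin beyond the scatter, and compound 2 is further away still, also beyond the scatter. Both of those carry halogens on the phenyl ring where compound 1 carries an ethyl.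

Compound 4 `Nc1nc(N)nc(-c2ccccc2I)n1` has not yet been measured in this assay. It differs from compound 1 by iodo in place of ethyl on an aromatic carbon. Among the compounds with values here, no step between measured compounds is available for this change, so the expectation rests on the halogen-bearing compounds 2 and 3 sitting well above compound 1. An upward step in this assay, of a size beyond the scatter, is expected. Compound 4 is estimated to give 60%, within a range from 25% to 95%. That estimate means an expected step of a number 40 percentage points higher from compound 1 to compound 4 (beyond the scatter).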

Compound 4, a percentage reported as inhibition, in the whole organism at one dose (the size of the read-out at that dose, not a potency): -7%
Estimate against measurement, compound 4: 67 percentage points above, and the stated range ends above it.
By their numbers in this assay, from the lowest: compound 4; then compound 1; then compound 3; then compound 2.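

Iodo in place of ethyl on an aromatic carbon gives a number 27 percentage points lower from compound 1 to compound 4 (beyond the scatter) in this assay and so provides the first measured step at this position. The step runs downward, and compound 4 gives -7% as the lowest number of the four, so iodo in this place does not raise the read-out over ethyl. Nothing available explains this fall.

The compounds shown leave open how an amine, a methoxy group or a carboxylic acid would compare with ethyl and iodo in the same place. They also leave open whether a longer chain there would fall above compound 1 or below compound 4.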